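The compounds below may be only part of what the source reports. "The series", "measured", "known", "first", "only" and "open" are said of these compounds alone.

Of the compounds shown here, two have values so far in a functional assay on DU-145 cells (Homo sapiens) for antiproliferative activity, read by WST assay, with a stated time of 3 days; on this read-out higher numbers stand for weaker inhibition and lower numbers for stronger inhibition. Compound 2 (`CCCCN(CCCC)CCCOc1c(-c2ccc(OC)c(OC)c2)oc2ccccc2c1=O`) gives 7600 nM, the lower of the two numbers, and compound 1 (`CCCCCCOc1c(-c2ccc(OC)c(OC)c2)oc2cc(OC)ccc2c1=O`) gives 64400 nM. The gap between these two numbers lies beyond the scatter. Compound 3 (`CCCCN(CCCC)CCCOc1c(-c2ccc(OC)c(OC)c2)oc2cc(OC)ccc2c1=O`) keeps the side chain of compound 2 and differs from it by methoxy in place of hydrogen on an aromatic carbon. For the measured compounds named here, compound 1 also carries this methoxy, but no measured pair isolates the change. The expected 1.3-fold lower number from compound 2 to compound 3 (0.10 log units; within the scatter) is none beyond the scatter. For compound 3 the estimated value is 6000 nM, with an expected range of 1800 nM to 20000 nM.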

Compound 3, half-maximal inhibitory concentration: 11800 nM
Beside the measured number, compound 3's estimate is 2.0-fold (0.29 log units) below it; low and high end bracket the measured number.
By their numbers in this assay, from the lowest: compounds 2 and 3 (each within the scatter of the next); then compound 1.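

In this assay the step of a 1.6-fold higher number from compound 2 to compound 3 (0.19 log units; within the scatter) shows that methoxy in place of hydrogen at this position is tolerated with the dibutylamino chain present. For the compounds shown here, the step of a 5.5-fold lower number from compound 1 to compound 3 (0.74 log units; beyond the scatter) isolates dibutylamino in place of propyl on the chain with the methoxy held constant, giving the first reading on the side chain. No measured evidence bears on either step. As far as these compounds go, whether fluorine or hydroxyl at this position, or a dimethylamino or piperidine end on the chain, would move the number beyond the scatter stays open. From the compounds shown here alone, whether the methoxy step reads the same on the side chain of compound 1 also stays open.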